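A few compounds are considered here, and "the series" means these few. Any claim that something is new, unique, unknown or untested is made for them only; others in the source may bear on it.

Compound 1, with the structure `CCn1c(CNc2ccccc2)nnc1SCC(=O)Nc1ccccc1`, was tested in an assay on isolated protein for inhibition of long-chain fatty acid transport protein 1 (Homo sapiens); on this read-out higher numbers stand for weaker inhibition and lower numbers for stronger inhibition. In this assay compound 1 gives only a limit, > 1000 nM, and no exact number. A second compound on the same core, compound 2 with the structure `CCC(O)c1ccc2oc(CSc3nnc(CNc4ccccc4)n3CC)nc2c1`, was tested in the same assay. Compound 2 also gives only a limit, > 1000 nM. Both values therefore sit at the limit of > 1000 nM in this assay, at which 2 of the 2 values shown sit, so compound 1 stands at the edge of what the assay can see, with nothing among the known numbers lying beyond it. The next compound, compound 3 with the structure `CCn1c(CNc2ccccc2)nnc1SCC(=O)Nc1ccc(OC)cc1`, differs from compound 1 by methoxy in place of hydrogen on an aromatic carbon. Going by the values given here, no measured pair shows what this change does, so the step from compound 1 to compound 3 in this assay is expected to be a step that the limit leaves unreadable from compound 1 to compound 3, likely none beyond the usual scatter. Compound 3 is therefore estimated at 3000 nM, most likely between 1000 nM and 20000 nM.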

Compound 3, half-maximal inhibitory concentration: > 1000 nM
Compound 3: no number, only a limit (the forecaster's own chance of this, stated with the estimate: 80%); the middle value lies beyond the limit too.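

Compound 1 and compound 3 each give only a limit in this assay, so no step can be read between them: the limit of > 1000 nM in this assay, at which 3 of the 3 values shown sit. The compounds shown leave open whether methoxy in place of hydrogen on an aromatic carbon changes inhibition at all, and how strongly any of these compounds inhibits.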